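Swapping Piperidin-4-yl for Methyl: An Untested Step

A few compounds are considered here, and "the series" means these few. Any claim that something is new, unique, unknown or untested is made for them only; others in the source may bear on it.

Three compounds have been measured in a functional assay on SK-BR-3 cells (Homo sapiens) for antiproliferative activity, read by MTT assay, with a stated time of 72 h; on this read-out lower numbers stand for stronger inhibition and higher numbers for weaker inhibition:

Compound 1 `CC(Nc1ncnc2ccc(-c3cnn(C4CCNCC4)c3)cc12)c1c(Cl)ccc(F)c1Cl` gives 4390 nM
Compound 2 `CC(Oc1nc(N)nc2ccc(-c3cnn(C4CCNCC4)c3)cc12)c1c(Cl)ccc(F)c1Cl` gives 7120 nM
Compound 3 `c1cnc2ccc(Nc3ncnc4ccc(-c5cnn(C6CCNCC6)c5)cc34)cc2c1` gives 2660 nM

Compound 3 shows the lowest number of the three. Within the data shown here, its nearest neighbour is compound 1, and the only single-point step in this set, a 1.7-fold lower number from compound 1 to compound 3 (0.22 log units; within the scatter), lies within the scatter, so the two cannot be ranked. Compound 2 sits further away, and its value against that of compound 3 lies beyond the scatter.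

Compound 4 `Cn1cc(-c2ccc3ncnc(Nc4ccc5ncccc5c4)c3c2)cn1` differs from compound 3 in one place: methyl in place of piperidin-4-yl on an aromatic nitrogen. Among the measured compounds shown here, no measured step touches this position; the one step on record, a 1.7-fold lower number from compound 1 to compound 3 (0.22 log units; within the scatter), concerns a different part of the shared core and so does not bear on the change. With no guide from the data, the expected step of a 1.5-fold higher number from compound 3 to compound 4 (0.18 log units; within the scatter) from compound 3 to compound 4 is set at no change beyond the scatter, with a wide range. For compound 4 the expected value in this assay is therefore 4000 nM, between 1300 nM and 13000 nM.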

Compound 4, half-maximal inhibitory concentration: 64 nM
Beside the measured number, compound 4's estimate is 63-fold (1.80 log units) above it; measured number outside the range, below it.
By their numbers in this assay, from the lowest: compound 4; then compounds 3, 1 and 2 (each within the scatter of the next, the first and the last beyond it).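

Among these compounds, this aromatic nitrogen turns out to be a highly sensitive position in this assay the change from piperidin-4-yl to methyl gives a 42-fold lower number from compound 3 to compound 4 (1.62 log units; beyond the scatter) and so far exceeds the only earlier step, which concerned another part of the molecule and stayed within the scatter. A single carbon in place of a six-membered non-aromatic ring is therefore compatible with a much lower number, at least with quinolin-6-yl on the shared core. Nothing on hand shows why the number falls so far.

An ethyl group, a 2-hydroxyethyl chain or a 2-aminoethyl chain on the same nitrogen would help show whether the size of the group or its amine matters. From the compounds shown here alone, it also remains open whether methyl acts the same way with the 1-(2,6-dichloro-3-fluorophenyl)ethyl group of compound 1.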